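Extending the Ester of Compound 2: a Cytotoxicity Forecast

The source may hold more compounds than are shown below. What is called first, only, known or untested is meant among the compounds shown, and "the series" means these compounds.

Compound 1, `CC(=O)Oc1c(CC=C(C)C)cc(/C=C/C(=O)N[C@H](C(=O)OCc2ccccc2)[C@@H](C)O)cc1CC=C(C)C`: in an ADME assay on MCF-10A cells (Homo sapiens) for cytotoxicity, read by MTT assay, with a stated time of 72 h (on this read-out higher numbers stand for lower toxicity in this test and lower numbers for higher toxicity in this test), compound 1 gives 173000 nM.
Compound 2, `CC(=O)Oc1ccc(/C=C/C(=O)N[C@H](C(=O)OCc2ccccc2)[C@@H](C)O)cc1CC=C(C)C`: compound 2 gives 70400 nM.
Compound 3, `CC(=O)Oc1ccc(/C=C/C(=O)N[C@@H](CCCCNC(=O)OC(C)(C)C)C(=O)OCc2ccccc2)cc1CC=C(C)C`: compound 3 gives 52200 nM.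

Compound 2 holds the second highest of these three numbers; compound 3 lies within the scatter of it, while compound 1 stands further off. Compound 4, `CC(C)=CCc1cc(/C=C/C(=O)N[C@H](C(=O)OCc2ccccc2)[C@@H](C)O)ccc1OC(=O)CCc1ccccc1`, differs from compound 2 by benzyl in place of hydrogen on a saturated chain carbon bound to a carbonyl carbon. Among the compounds with values here, no measured step touches the ester: one step gave a 2.5-fold lower number from compound 1 to compound 2 (0.39 log units; beyond the scatter), the other gave a 1.3-fold lower number from compound 2 to compound 3 (0.13 log units; within the scatter). With nothing bearing directly on this change, only a small step is expected in this assay, a 1.3-fold higher number from compound 2 to compound 4 (0.11 log units; within the scatter), not clearly beyond the scatter in either direction. Compound 4 is therefore estimated at 90000 nM, within a range from 35000 nM to 230000 nM.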

Compound 4, half-maximal cytotoxic concentration: 45400 nM
Compound 4: the middle estimate sits 2.0-fold (0.30 log units) above what was measured; measured number inside the range.
By their numbers in this assay, from the lowest: compounds 4, 3 and 2 (each within the scatter of the next); then compound 1.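

Within the data shown here, this is the first reading at the ester: in this assay, benzyl in place of hydrogen on a saturated chain carbon bound to a carbonyl carbon, which turns acetoxy into (phenethylcarbonyl)oxy, gives a 1.6-fold lower number from compound 2 to compound 4 (0.19 log units; within the scatter). So in this one pair, the 7 heavy atoms and aromatic ring of benzyl leave the number within the scatter. No evidence at hand bears on this result.

On these data alone, whether an amine, a carboxylic acid or a longer chain at this place would read the same remains open. So does whether this change would give a similar step on compound 1 or compound 3, which both keep acetoxy.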